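Acyl groups on the side-chain oxygen: estimating compound 3

This account rests on a few compounds, and the source may have more. Where it says the series, first, only, none or still open, it means among the compounds named here.

Measured so far:
- compound 1 `CC(=O)OCCO[C@H](CC=C(C)C)C1=CC(=O)c2c(O)ccc(O)c2C1=O`: 41500 nM
- compound 2 `CC(C)=CC[C@@H](OC(=O)CC(C)(O)C(C)C)C1=CC(=O)c2c(O)ccc(O)c2C1=O`: 27700 nM

In a functional assay on HeLa cells (Homo sapiens) for cytotoxicity, read by MTT assay (on this read-out higher numbers stand for weaker inhibition and lower numbers for stronger inhibition), compound 1 gives 41500 nM, the highest of the two numbers recorded. Compound 2 gives 27700 nM, and the step of a 1.5-fold lower number from compound 1 to compound 2 (0.18 log units; within the scatter) stays within the scatter, so the two compounds cannot be ordered.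

Compound 3 `CC(C)=CC[C@@H](OC(=O)C1CCCCO1)C1=CC(=O)c2c(O)ccc(O)c2C1=O` is the next member. It differs from compound 1 as follows: (oxan-2-yl)carbonyl in place of 2-acetoxyethyl on an oxygen on a saturated carbon

Among the measured compounds shown here, the one measured step that bears on this change is a 1.5-fold lower number from compound 1 to compound 2 (0.18 log units; within the scatter). It too replaces the 2-acetoxyethyl on the same oxygen by an acyl group, and it produced no shift beyond the scatter. For the measured compounds named here, with no step that moved the read-out appreciably, no step beyond the scatter is expected for compound 3 either.

Compound 3 is therefore estimated at 32000 nM, with a range from 12000 nM to 80000 nM, which corresponds to an expected step of a 1.3-fold lower number from compound 1 to compound 3 (0.11 log units; within the scatter).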

Compound 3, half-maximal inhibitory concentration: > 100000 nM
Compound 3: a limit, no number (the forecaster's own chance of this, stated with the estimate: 10%); middle value at least 3.1-fold (0.49 log units) from the limit.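

In this assay compound 3 gives > 100000 nM, which is a limit of the assay and not a number. Replacing the group on this oxygen can therefore move the read-out beyond the scatter, with an at least 2.4-fold higher number from compound 1 to compound 3 (0.38 log units; beyond the scatter) and, between the two acyl groups on the carbonyl carbon, an at least 3.6-fold higher number from compound 2 to compound 3 (0.55 log units; beyond the scatter). Compound 1 and compound 2 could not be ordered, so the acyl groups at this position are not interchangeable, and the reading for compound 3 sits at the end of the measurable range: the limit of > 100000 nM in this assay, at which 1 of the 3 values shown sits.

Going by these compounds, how far compound 3 lies past that limit stays open. Also open, on these data alone, is whether the shift follows the six-membered ring or its ring oxygen, which a cyclohexylcarbonyl group on the same oxygen would separate.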